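The source may hold more compounds than are shown below. What is called first, only, known or untested is meant among the compounds shown, and "the series" means these compounds.

Measured so far:
- compound 1 `COc1cc(/C=C/C(=O)c2cccc(NC(=O)c3cccs3)c2)ccc1O`: 90%
- compound 2 `COc1cc(/C=C/C(=O)c2cccc(NC(=O)c3ccco3)c2)ccc1O`: 100%
- compound 3 `COc1cc(/C=C/C(=O)c2cccc(N)c2)ccc1O`: 90%

In a functional assay on HUVEC cells (Homo sapiens) for inhibition, tested at 10 ug/mL (a lower number here means a weaker effect, a higher number a stronger effect of the compound at the concentration tested), compound 3 sits level with compound 1 at the digits printed, the two together being the lowest of the three numbers; the step of no change at the digits printed from compound 1 to compound 3 (within the scatter) and the step of a number 10 percentage points lower from compound 2 to compound 3 (within the scatter) are both within the scatter, so no ordering among the three is supported.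

Compound 4 `COc1cc(/C=C/C(=O)c2cccc(NC(=O)c3ccc(Cl)c(Cl)c3)c2)ccc1O` differs from compound 3 by (3,4-dichlorophenyl)carbonyl in place of hydrogen on a nitrogen on an aromatic ring. The two steps that bear on this change are the reverse of no change at the digits printed from compound 1 to compound 3 (within the scatter) and of a number 10 percentage points lower from compound 2 to compound 3 (within the scatter), where an aryl carbonyl on the same nitrogen left without a change beyond the scatter. Adding the (3,4-dichlorophenyl)carbonyl at that nitrogen is therefore expected to give no step beyond the scatter in this assay. The expected step is a number 5 percentage points higher from compound 3 to compound 4 (within the scatter). Compound 4 is thus estimated at 95%, within 85% to 100%.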

Compound 4, a percentage reported as inhibition, at one concentration (the size of the read-out at that concentration, not a potency): 45%
The estimate for compound 4 lay 50 percentage points above the measured number, and the stated range ends above it.
By their numbers in this assay, from the lowest: compound 4; then compounds 1, 3 and 2 (each within the scatter of the next).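

In this assay the nitrogen on the aromatic ring does not accept every aryl carbonyl: (3,4-dichlorophenyl)carbonyl gives a number 45 percentage points lower from compound 3 to compound 4 (beyond the scatter) while the thiophen-2-yl and furan-2-yl amides stayed within the scatter of the free amine. The group on the carbonyl carbon therefore matters, with a number 55 percentage points lower from compound 2 to compound 4 (beyond the scatter) and a number 45 percentage points lower from compound 1 to compound 4 (beyond the scatter) when 3,4-dichlorophenyl replaces the furan-2-yl and thiophen-2-yl groups. Nothing available explains this loss.

From the compounds shown here alone, whether it belongs to the chlorine atoms or to the phenyl ring stays open; an unsubstituted phenyl or a single chlorine would separate the two. Going by these compounds, how an acetyl or a longer alkyl chain on the same carbonyl reads is also open.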